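This account rests on a few compounds, and the source may have more. Where it says the series, first, only, none or still open, it means among the compounds named here.

Read-outs in an ADME assay on microsomes from liver (Homo sapiens) for metabolic stability (on this read-out lower numbers stand for slow clearance and higher numbers for fast clearance), so far:
compound 1 `Cc1ccc(NC(=O)c2cc(Oc3ccc(S(C)(=O)=O)cc3)cc(OC(C)C)c2)nc1` gives 17 mL/min/kg
compound 2 `CC(C)Oc1cc(Oc2ccc(S(C)(=O)=O)cc2)cc(-c2cncc(=O)[nH]2)c1` gives 11 mL/min/kg
compound 3 `CC(C)Oc1cc(Oc2cnc(C(=O)N(C)C)nc2)cc(-c2nccc(=O)[nH]2)c1` gives < 8 mL/min/kg

Compound 3 has no number here, and its reading is the limit of < 8 mL/min/kg in this assay, at which 1 of the 3 values shown sits, in this short series. Compound 4 `CCC(CC)Oc1cc(Oc2cnc(C(=O)N(C)C)nc2)cc(-c2nccc(=O)[nH]2)c1` is still unmeasured. Relative to compound 3 it carries pentan-3-yl in place of isopropyl on an oxygen on an aromatic ring and nothing else differs.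

Going by the values given here, the only measured step with a single change is a 1.5-fold lower number from compound 1 to compound 2 (0.19 log units; within the scatter) and it lies within the scatter. That step sits on an aromatic carbon and not on this oxygen. Among the compounds with values here, no measured pair varies the group on the oxygen, so no measured step gives a size to carry over.

For compound 3 the reading of < 8 mL/min/kg is a limit. From the larger pentan-3-yl alone, a modest rise in this assay is expected, on the scale of the scatter or a little past it. The expected change is an at least 1.2-fold higher number from compound 3 to compound 4 (0.09 log units; that floor lies within the scatter) as an estimate only. Estimated for compound 4 is 10 mL/min/kg within 7 mL/min/kg to 20 mL/min/kg as the expected range.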

Compound 4, clearance: 22.4 mL/min/kg
Compound 4: the middle estimate sits 2.2-fold (0.35 log units) below what was measured; measured number above the stated range.
By their numbers in this assay, from the lowest: compounds 2, 1 and 4 (each within the scatter of the next, the first and the last beyond it). At a limit, below all of these: compound 3.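

In this assay, going by these compounds alone, pentan-3-yl in place of isopropyl on this oxygen is the first single change with a step beyond the scatter (an at least 2.8-fold higher number from compound 3 to compound 4 (0.44 log units; beyond the scatter)). The only earlier single-change step lay on an aromatic carbon and stayed within the scatter, so the oxygen is the one place shown where a single change moves this read-out clearly, and it does so with only a carbon chain changing, no ring and no hydrogen-bond donor or acceptor entering or leaving. The size of the step is only a floor, and the true gap may be larger, as the reading for compound 3 is a limit: the limit of < 8 mL/min/kg in this assay, at which 1 of the 4 values shown sits.

Open, as far as these compounds go, is whether the rise follows the size of the group on the oxygen or its branching, which a straight pentyl chain, a cyclopentyl ring or a smaller ethyl group at the same place would begin to separate. Also open, from the compounds shown here alone, is whether the step carries over to other cores, such as that of compound 2 with its methylsulfonyl-bearing ring, and whether a hydroxyl or an ether oxygen in the longer chain changes its size.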